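The source may hold more compounds than are shown below. What is called first, only, known or untested is meant among the compounds shown, and "the series" means these compounds.

Among the measured compounds shown here, compound 3 `O=C(C1=C(Nc2ccc(F)cc2)C(=O)N(CCCn2ccnc2)C1c1ccc(Br)cc1)c1ccccc1` stands highest of the three numbers so far recorded in a functional assay on SAOS-2 cells (Homo sapiens) for antiproliferative activity, read by MTT assay, with a stated time of 72 h; on this read-out higher numbers stand for weaker inhibition and lower numbers for stronger inhibition. In this assay compound 3 gives 32700 nM. Its nearest neighbour is compound 2 `O=C(C1=C(OC2CCCCC2)C(=O)N(CCCn2ccnc2)C1c1ccc(Br)cc1)c1ccccc1`, which in this assay gives 29700 nM, a value within the scatter of that of compound 3. The furthest is compound 1 `CCCCOC1=C(C(=O)c2ccccc2)C(c2ccc(Br)cc2)N(CCCn2ccnc2)C1=O`, which in this assay gives 11600 nM. The steps leading to compound 3 are modest: a 2.8-fold higher number from compound 1 to compound 3 (0.45 log units; beyond the scatter), and a 1.1-fold higher number from compound 2 to compound 3 (0.04 log units; within the scatter), the latter within the scatter. For comparison, a 2.6-fold higher number from compound 1 to compound 2 (0.41 log units; beyond the scatter).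

Compound 4 `O=C(C1=C(Nc2ccccc2Br)C(=O)N(CCCn2ccnc2)C1c1ccc(Br)cc1)c1ccccc1` differs from compound 3 in one place: 2-bromophenyl in place of 4-fluorophenyl on an amine nitrogen. For the measured compounds named here, none of the measured steps changes the aryl group on that amine nitrogen once an arylamino group is present; the two steps that reach this position, from compound 1 and from compound 2, only introduce the (4-fluorophenyl)amino group, and both were modest or within the scatter. Going by the values given here, there is thus no measured step that speaks for a shift in either direction, and no step beyond the scatter is expected in this assay. The expected step is estimated as a 1.1-fold lower number from compound 3 to compound 4 (0.04 log units; within the scatter). Compound 4 is therefore expected to give about 30000 nM in this assay, within a range from 12000 nM to 75000 nM.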

Compound 4, half-maximal inhibitory concentration: 19600 nM
The estimate for compound 4 lay 1.5-fold (0.18 log units) above the measured number; measured number inside the range.
By their numbers in this assay, from the lowest: compounds 1, 4, 2 and 3 (each within the scatter of the next, the first and the last beyond it).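

In this assay, the exchange of 4-fluorophenyl for 2-bromophenyl on the amine nitrogen is the first step shown that alters the aryl group itself, and it stays within the scatter (a 1.7-fold lower number from compound 3 to compound 4 (0.22 log units; within the scatter)). Compound 4 also cannot be separated from either oxygen-linked compound, as the steps to it show (a 1.5-fold lower number from compound 2 to compound 4 (0.18 log units; within the scatter)) and (a 1.7-fold higher number from compound 1 to compound 4 (0.23 log units; within the scatter)), whereas the (4-fluorophenyl)amino group stands beyond the scatter from butoxy (a 2.8-fold higher number from compound 1 to compound 3 (0.45 log units; beyond the scatter)), so an arylamino group at this place does not by itself set a compound apart from compound 1. No measurement offered here accounts for these numbers.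

The step from compound 3 to compound 4 changes both the halogen and its place on the ring, so the compounds shown cannot tell these two changes apart, and a plain phenyl on the same nitrogen would give the missing reference point. Going by these compounds, how a butylamino group, with a chain in place of the aryl ring, would compare with butoxy at this carbon also stays open.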